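Ring swap at the amine position of the sulfonyl core

The source may hold more compounds than are shown below. What is called first, only, known or untested is meant among the compounds shown, and "the series" means these compounds.

Measured compounds:
compound 1 `CC1CCN(c2c(S(=O)(=O)c3ccccc3)cnc3ccccc23)CC1`: 108 nM
compound 2 `CCOC(=O)C1CCN(c2c(S(=O)(=O)c3ccccc3)cnc3ccccc23)CC1`: "not determined" (no result reported)
compound 3 `CCN1CCN(c2c(S(=O)(=O)c3ccccc3)cnc3ccccc23)CC1`: "not determined" (no result reported)

In an assay on isolated protein for displacement of a labelled ligand from metabotropic glutamate receptor 5 (Homo sapiens), with a stated time of 60 min (on this read-out higher numbers stand for weaker inhibition and lower numbers for stronger inhibition), compound 1 gives 108 nM. For compound 2 and compound 3 the read-out is "not determined" (no result reported), so compound 3 stands without a number, and nothing beyond the shared core can be said of its place in the series. Compound 4 `O=S(=O)(c1ccccc1)c1cnc2ccccc2c1N1CCCCCC1` is not yet measured. It differs from compound 3 as follows (azepan-1-yl in place of 4-ethylpiperazin-1-yl on an aromatic carbon). Among the measured compounds shown here, with no number for compound 3, the size and direction of the step cannot be set from the data; the only anchor is compound 1, whose 108 nM comes from the same core carrying a different six-membered saturated ring. On that basis compound 4 is expected to give about 150 nM in this assay, in a range from 40 nM to 600 nM.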

Compound 4, inhibition constant: 310 nM
Compound 4: the middle estimate sits 2.1-fold (0.32 log units) below what was measured, within the range that was stated.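

In this assay, the seven-membered azepan-1-yl ring on this aromatic carbon still gives a measurable value, but replacing 4-methylpiperidin-1-yl gives a 2.9-fold higher number from compound 1 to compound 4 (0.46 log units; beyond the scatter). Steps involving compound 2 or compound 3 cannot be read, as neither has a number. No measured evidence accounts for this step.

Compound 4 changes the ring size and removes the methyl group together, leaving their separate contributions unresolved. Going by these compounds, an unsubstituted piperidin-1-yl ring would separate them, and how morpholin-4-yl behaves at this position remains open.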